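A few compounds are considered here, and "the series" means these few. Any claim that something is new, unique, unknown or untested is made for them only; others in the source may bear on it.

Compound 1 `O=C1c2ccccc2S(=O)(=O)N1CCCCCCN1CCN(c2ccccc2Cl)CC1` is the reference point of this small set. In an ADME assay on HEK293 cells for displacement of a labelled ligand from 5-hydroxytryptamine receptor 7 (Homo sapiens), read by radioligand binding, with a stated time of 1 h (on this read-out higher numbers stand for weaker inhibition and lower numbers for stronger inhibition), compound 1 gives 120 nM, and compound 2 `O=C1c2ccccc2S(=O)(=O)N1CCCCCCN1CCN(c2ccccc2)CC1` gives 192 nM in this assay. Going by the values given here, the one measured step, a 1.6-fold higher number from compound 1 to compound 2 (0.20 log units; within the scatter), exchanges hydrogen for chloro on an aromatic carbon and stays within the scatter. Compound 1 therefore stands at the lower of the two numbers recorded, with compound 2 as its nearest neighbour, and the two are not separable on these data.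

Compound 3 `O=C1c2ccccc2S(=O)(=O)N1CCCCCCN1CCN(c2cccc3cccnc23)CC1` differs from compound 1 in one place: quinolin-8-yl in place of 2-chlorophenyl on an amine nitrogen in a ring. The step from compound 1 to compound 2 touches the same group that is replaced here, and it showed no change beyond the scatter, so the group on the amine nitrogen in the ring tolerates at least a small alteration. Among the compounds with values here, no measured step covers an exchange of the whole group for quinolin-8-yl, so the expectation rests on that tolerance alone. The number for compound 3 is expected to stay close to that of compound 1, with an expected step of a 1.2-fold lower number from compound 1 to compound 3 (0.08 log units; within the scatter). Compound 3 is thus estimated at 100 nM, in a range from 30 nM to 350 nM.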

Compound 3, inhibition constant: 21 nM
For compound 3 the middle estimate is 4.8-fold (0.68 log units) above the measured one, and the stated range ends above it.
By their numbers in this assay, from the lowest: compound 3; then compounds 1 and 2 (each within the scatter of the next).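

In this assay, this position on the amine nitrogen in the ring now shows a change beyond the scatter: quinolin-8-yl in place of 2-chlorophenyl gives a 5.7-fold lower number from compound 1 to compound 3 (0.76 log units; beyond the scatter), and quinolin-8-yl in place of phenyl gives a 9.1-fold lower number from compound 2 to compound 3 (0.96 log units; beyond the scatter). Going by these compounds alone, the earlier step showed only that removing the chloro group left the number within the scatter, whereas exchanging the whole group moves it towards stronger inhibition, so the position is sensitive to what is placed there. The entering group brings more heavy atoms, a second six-membered aromatic ring with one hetero atom, and a hydrogen-bond acceptor, but no available evidence indicates which of these differences accounts for the lower number.

From the compounds shown here alone, what remains open is whether the second ring alone is enough or whether its ring nitrogen also matters, a question that a naphthalen-1-yl group on the same nitrogen would help to separate. Going by these compounds, it is also open whether quinolin-8-yl would give a similar step with a shorter chain in place of the present one.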